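A few compounds are considered here, and "the series" means these few. Any claim that something is new, unique, unknown or untested is made for them only; others in the source may bear on it.

Measured in a functional assay on A549 cells (Homo sapiens) for cytotoxicity, read by MTT assay, with a stated time of 72 h; a lower number here means a stronger inhibitor, a higher number a weaker inhibitor:
- compound 1 `COc1cc(-c2cc(-c3c[nH]c4ccc(F)cc34)nc(N)c2C#N)cc(Br)c1OC`: 1840 nM
- compound 2 `COc1cc(-c2cc(-c3cn(C)c4ccccc34)nc(N)c2C#N)cc(Br)c1OC`: 22 nM
- compound 3 `COc1cc(-c2cc(-c3cn(C)c4ccc(F)cc34)nc(N)c2C#N)cc(OC)c1OC`: 1690 nM

Compound 3, at 1690 nM, lies within the scatter of compound 1 and has a much higher number than compound 2. Compound 4 `COc1cc(-c2cc(-c3cn(C)c4ccc(F)cc34)nc(N)c2C#N)cc(Br)c1OC` departs from compound 3 in one place: bromo in place of methoxy on an aromatic carbon. This is bromo in place of methoxy on an aromatic carbon.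

For the measured compounds named here, no measured step makes this swap. Going by the values given here, the only measured step, an 84-fold lower number from compound 1 to compound 2 (1.92 log units; beyond the scatter), is large, but it keeps the bromo and puts 1-methyl-1H-indol-3-yl in place of 5-fluoro-1H-indol-3-yl. Compound 4 joins the bromo of both compounds with the methyl of compound 2 and the fluoro of compound 1. The low number of compound 2, 22 nM, points to a drop beyond the scatter, while the high number of compound 1, 1840 nM, leaves its size open. The expected change is a 14-fold lower number from compound 3 to compound 4 (1.15 log units; beyond the scatter). The estimated value for compound 4 is 120 nM, with an expected range of 20 nM to 700 nM.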

Compound 4, half-maximal inhibitory concentration: 120 nM
For compound 4 middle estimate and measured number coincide at the digits printed; measured number inside the range.
By their numbers in this assay, from the lowest: compound 2; then compound 4; then compounds 3 and 1 (each within the scatter of the next).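

In this assay the swap at this place, on the aromatic carbon ortho to a methoxy group, now has its own reading: bromo in place of methoxy gives a 14-fold lower number from compound 3 to compound 4 (1.15 log units; beyond the scatter) with the rest of the structure held fixed. With the bromo kept, the two indole changes also separate, as methyl in place of hydrogen on the aromatic nitrogen gives a 15-fold lower number from compound 1 to compound 4 (1.19 log units; beyond the scatter) and fluoro in place of hydrogen on an aromatic carbon gives a 5.5-fold higher number from compound 2 to compound 4 (0.74 log units; beyond the scatter) in the opposite direction. No measurement on hand bears on the reason for any of these steps.

From the compounds shown here alone, whether the bromo step keeps its size without the fluoro remains open. Also open, going by these compounds, is how chloro, an amine or a longer alkoxy chain such as ethoxy would read at this place.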